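The compounds below may be only part of what the source reports. "The series", "measured", "known", "first", "only" and "open" are said of these compounds alone.

Working notes on the series. Compound 2 `CCC1=C(O)c2c(oc(-c3ccc(F)cc3)cc2=O)C(CC)(CC)C1=O` gives, in a functional assay on KB cells (Homo sapiens) for antiproliferative activity, read by sulforhodamine B assay, with a stated time of 3 days (on this read-out higher numbers stand for an effect only at larger amounts of compound and lower numbers for an effect already at smaller amounts), 33 uM. On the numbers shown it stands lowest of two, though its nearest neighbour compound 1 `CCC1=C(O)c2c(oc(-c3ccc(C(F)(F)F)cc3)cc2=O)C(CC)(CC)C1=O` with 35.7 uM lies within the scatter of it, so no order between them can be read. Among the measured compounds shown here, the single step on record, a 1.1-fold lower number from compound 1 to compound 2 (0.03 log units; within the scatter), shows that swapping one para substituent for another on the pendant aryl ring left this assay essentially unchanged. Compound 3 `CCC1=C(O)c2c(oc(-c3ccc(C)c(Cl)c3)cc2=O)C(CC)(CC)C1=O` differs from compound 2 by 3-chloro-4-methylphenyl in place of 4-fluorophenyl on an aromatic carbon. For the measured compounds named here, this replaces a para substituent with two groups in a different pattern, a change on which nothing measured bears directly; the one recorded step suggests aryl substitution matters little here, so the expected step of a 1.3-fold lower number from compound 2 to compound 3 (0.12 log units; within the scatter) is small. Compound 3 is therefore estimated at 25 uM, in the range 8 uM to 80 uM, before measurement.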

Compound 3, concentration for half-maximal effect: 39 uM
Compound 3: middle estimate off by 1.6-fold (0.19 log units), on the low side; low and high end bracket the measured number.
By their numbers in this assay, from the lowest: compounds 2, 1 and 3 (each within the scatter of the next).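

In this assay, the step with 3-chloro-4-methylphenyl in place of 4-fluorophenyl is a 1.2-fold higher number from compound 2 to compound 3 (0.07 log units; within the scatter). On the aromatic carbon next to the ring oxygen, a change to a two-substituent aryl group with chlorine and methyl therefore stays as indistinguishable as the earlier exchange of one single substituent for another. No measurement available here bears on the reason for this.

Still open, from the compounds shown here alone, is whether an amine or a carboxylic acid on this aryl ring would move the number beyond the scatter. Going by these compounds, replacing the aryl group with a longer alkyl chain is equally open.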